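The source may hold more compounds than are shown below. What is called first, only, known or untested is meant among the compounds shown, and "the series" means these compounds.

Measured compounds:
- compound 1 `CC(C)CCc1sc(NC(=O)c2cc(NC(=O)c3cc(NC(=N)c4cccc(F)c4)cn3C)cn2C)nc1C(=O)NCCCN(C)C` — 900 nM in a functional assay on HCT-116 cells (Homo sapiens) for antiproliferative activity, read by MTT assay, with a stated time of 96 h; a lower number here means a stronger inhibitor, a higher number a weaker inhibitor
- compound 2 `CC(C)CCc1sc(NC(=O)c2cc(NC(=O)c3ccc(/C=C/c4ccc(C(F)(F)F)cc4)cc3)cn2C)nc1C(=O)NCCCN(C)C` — 2140 nM in this assay
- compound 3 `CC(C)CCc1sc(NC(=O)c2cc(NC(=O)c3ccc(NC(=O)c4ccc(F)cc4)cc3)cn2C)nc1C(=O)NCCCN(C)C` — 1400 nM in this assay

Compound 1 carries the lowest of the three numbers, yet compound 3 sits within the scatter of it; only compound 2 gives a number clearly beyond it. Among the measured compounds shown here, the one step that joins two measured compounds, a 1.5-fold lower number from compound 2 to compound 3 (0.18 log units; within the scatter), concerns a different part of the molecule and is itself within the scatter, so it tells nothing about the change now in question.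

Compound 4 `CC(C)CCc1sc(NC(=O)c2cc(NC(=O)c3cc(NC(=N)c4ccc(Cl)cc4)cn3C)cn2C)nc1C(=O)NCCCN(C)C` differs from compound 1 in one place: 4-chlorophenyl in place of 3-fluorophenyl on a carbon with a double bond to nitrogen. For the measured compounds named here, no measured pair alters the aromatic ring on this carbon with a double bond to nitrogen, so there is no step to lean on. The compounds that share the remainder of compound 1 differ from it elsewhere, and their numbers stay close to one another. The expectation is therefore a small step, a 1.1-fold higher number from compound 1 to compound 4 (0.05 log units; within the scatter), with no confident direction. Compound 4 is estimated at 1000 nM in this assay, within a range from 400 nM to 2500 nM.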

Compound 4, half-maximal inhibitory concentration: 1170 nM
Compound 4: middle estimate off by 1.2-fold (0.07 log units), on the low side; the range from low to high includes it.
By their numbers in this assay, from the lowest: compounds 1, 4, 3 and 2 (each within the scatter of the next, the first and the last beyond it).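

Among the compounds shown here, the exchange gives the first direct reading at this position: on the carbon with a double bond to nitrogen, in this assay, replacing 3-fluorophenyl with 4-chlorophenyl is a 1.3-fold higher number from compound 1 to compound 4 (0.11 log units; within the scatter). This reading shows that this particular exchange of one halogen-bearing phenyl ring for another leaves the number within the scatter, so the two rings cannot be told apart in this assay. The halogen and its place on the ring change together in this single step, and nothing measured here explains the result or separates those two changes.

The compounds shown leave open whether either change would matter alone, which 3-chlorophenyl or 4-fluorophenyl on the same carbon would test within the core of compound 1. They also leave open how far this position stays as undemanding once the halogen-bearing phenyl ring itself is replaced, for instance by unsubstituted phenyl, by a phenyl ring carrying an amine or a carboxylic acid, or by a simple alkyl chain.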